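One ring swap, measured once, expected again

A few compounds are considered here, and "the series" means these few. Any claim that something is new, unique, unknown or untested is made for them only; others in the source may bear on it.

In a functional assay on NCI-H460 cells (Homo sapiens) for cytotoxicity, read by MTT assay (on this read-out lower numbers stand for stronger inhibition and higher numbers for weaker inhibition), compound 1 `Cc1nc(Nc2ccc(Cl)c(Cl)c2)sc1C(=O)/C=C/c1ccccc1` gives 22700 nM. Compound 2 `Cc1cccc(Nc2nc(C)c(C(=O)/C=C/c3ccccc3)s2)c1` differs from compound 1 by 3-methylphenyl in place of 3,4-dichlorophenyl on a nitrogen on an aromatic ring and in this assay compound 2 gives 21800 nM, a step of a 1.0-fold lower number from compound 1 to compound 2 (0.02 log units; within the scatter). Compound 3 `Cc1nc(Nc2ccc(Cl)c(Cl)c2)sc1C(=O)/C=C/c1ccc(Cl)cc1` differs from compound 1 by chloro in place of hydrogen on an aromatic carbon; that is how the two cores differ. For compound 3 this assay reports only a limit, > 25000 nM, and no number. Set against compound 1 this reads as an at least 1.1-fold higher number from compound 1 to compound 3 (0.04 log units; that floor lies within the scatter), and it rests on (the limit of > 25000 nM in this assay, at which 1 of the 3 values shown sits).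

Compound 4 `Cc1cccc(Nc2nc(C)c(C(=O)/C=C/c3ccc(Cl)cc3)s2)c1` is not yet measured in this assay. It stands to compound 3 as compound 2 stands to compound 1: the change is 3-methylphenyl in place of 3,4-dichlorophenyl on a nitrogen on an aromatic ring, at the same place, so it is the same change, seen for two pairs here. Because a 1.0-fold lower number from compound 1 to compound 2 (0.02 log units; within the scatter) lay within the scatter, the step from compound 3 to compound 4 is expected to be small. Because compound 3 sits at the limit of > 25000 nM in this assay, at which 1 of the 3 values shown sits, compound 4 is expected to give about 30000 nM, likely between 15000 nM and 60000 nM. That estimate means an expected step that the limit leaves unreadable from compound 3 to compound 4, with a fair chance that only a limit is reported again.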

Compound 4, half-maximal inhibitory concentration: > 25000 nM
Compound 4 was reported as a limit (the forecaster's own chance of this, stated with the estimate: 65%); the middle value does not contradict the limit.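

In this assay, putting chloro in place of hydrogen on an aromatic carbon gives an at least 1.1-fold higher number from compound 2 to compound 4 (0.05 log units; that floor lies within the scatter), while the step from compound 3 to compound 4 cannot be read, since both compounds are reported only as limits. This means the swap from 3,4-dichlorophenyl to 3-methylphenyl, which stayed within the scatter on the core of compound 1, is neither confirmed nor contradicted on the core of compound 3, and the chloro change can be compared across two cores only as far as the limits allow: the same change on two cores in this assay, an at least 1.1-fold higher number (0.04 log units; that floor lies within the scatter) from compound 1 to compound 3 and an at least 1.1-fold higher number (0.05 log units; that floor lies within the scatter) from compound 2 to compound 4; the limit leaves it open whether they differ. Neither change is shown to carry over from one core to another with the same size, and half of the picture rests on a single assay limit: the limit of > 25000 nM in this assay, at which 2 of the 4 values shown sit.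

The compounds shown leave open whether any change in this series gives a clearly lower number in this assay. From the compounds shown here alone, it also remains open what an amine or a carboxylic acid in place of the chloro, or a longer chain in place of the methyl, would do.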